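Swapping Trifluoromethyl for Methyl in a Small Cytotoxic Series

The source may report more compounds than this note shows. Statements on the series, on what has been measured and on what is new or still open speak of the compounds shown alone.

Three measured candidates share one core and differ only in what sits on their aromatic ring. In a functional assay on PCa 2b cells (Homo sapiens) for cytotoxicity, read by MTT assay, with a stated time of 72 h (a higher number here means a weaker inhibitor, a lower number a stronger inhibitor), compound 1 (`CC1=C(/C=C/C(=O)/C=C/c2cccc(C(F)(F)F)c2)C(C)(C)CCC1O`) gives 2600 nM, and compound 2 (`CC1=C(/C=C/C(=O)/C=C/c2cc(C(F)(F)F)ccc2C(F)(F)F)C(C)(C)CCC1O`) gives 4000 nM. Among the measured compounds shown here, these are the only two numbers available, and they lie within the usual scatter of each other, so they do not separate the two compounds. The result for compound 3 (`CC1=C(/C=C/C(=O)/C=C/c2cccc(C(F)(F)F)c2F)C(C)(C)CCC1O`) is "not determined" (no result reported) and offers no guidance.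

The next compound to be tested is compound 4 (`CC1=C(/C=C/C(=O)/C=C/c2cccc(C)c2)C(C)(C)CCC1O`). Its difference from compound 1 is methyl in place of trifluoromethyl on an aromatic carbon. For the measured compounds named here, the only measured step involving trifluoromethyl is a 1.5-fold higher number from compound 1 to compound 2 (0.19 log units; within the scatter). That step puts trifluoromethyl in place of hydrogen rather than making the swap at hand, so it is only a loose guide. On this small step to compound 2, no change beyond the scatter is expected in this assay, and no direction can be favoured. The expected step is a 1.2-fold higher number from compound 1 to compound 4 (0.06 log units; within the scatter). For compound 4 the estimated value is 3000 nM, with an expected range from 1200 nM to 7500 nM.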

Compound 4, half-maximal inhibitory concentration: 19000 nM
The estimate for compound 4 lay 6.3-fold (0.80 log units) below the measured number; the whole stated range lies below it.
By their numbers in this assay, from the lowest: compounds 1 and 2 (each within the scatter of the next); then compound 4.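

Among the compounds shown here, at this place on the ring, meta to a large group, replacing trifluoromethyl with methyl gives the first step in this assay that clearly exceeds the scatter: a 7.3-fold higher number from compound 1 to compound 4 (0.86 log units; beyond the scatter). The earlier step, a 1.5-fold higher number from compound 1 to compound 2 (0.19 log units; within the scatter), came from adding a second trifluoromethyl group to the ring and did not separate its two compounds, whereas this single exchange does, with compound 1 being the stronger inhibitor of the pair. The exchange removes three fluorine atoms and takes the group from four heavy atoms to one, but nothing measured here explains why the number shifts.

For the compounds shown here, only one pair of compounds tests this exchange, so it cannot show whether the shift tracks the fluorine atoms or the size of the group, and it says nothing about the same exchange elsewhere on the ring or on another core. Going by these compounds, how a chlorine atom, a methoxy group or an amine at this same place would compare with methyl and trifluoromethyl also remains open.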